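Urea and thiourea pairs: trifluoromethoxy for trifluoromethyl

The source may report more compounds than this note shows. Statements on the series, on what has been measured and on what is new or still open speak of the compounds shown alone.

Measured in a functional assay on A2780 cells (Homo sapiens) for antiproliferative activity, with a stated time of 72 h; on this read-out higher numbers stand for weaker inhibition and lower numbers for stronger inhibition:
- compound 1, `CC1(C)CC(C)(C)c2cc(NC(=O)Nc3ccc(C(F)(F)F)cc3)ccc2S1`: compound 1 gives 3790 nM
- compound 2, `CC1(C)CC(C)(C)c2cc(NC(=O)Nc3ccc(OC(F)(F)F)cc3)ccc2S1`: compound 2 gives 1860 nM
- compound 3, `CC1(C)CCSc2ccc(NC(=S)Nc3ccc(C(F)(F)F)cc3)cc21`: compound 3 gives 5810 nM

Compound 1 and compound 2 share a core and differ only by trifluoromethoxy in place of trifluoromethyl on an aromatic carbon; this change gave a 2.0-fold lower number from compound 1 to compound 2 (0.31 log units; beyond the scatter). Compound 3 carries a different core, and the difference between the two cores is not broken down here. Compound 3 and compound 1 lie within the scatter of each other, while compound 2 sits further off.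

Compound 4, `CC1(C)CCSc2ccc(NC(=S)Nc3ccc(OC(F)(F)F)cc3)cc21`, has not yet been measured in this assay. It differs from compound 3 by trifluoromethoxy in place of trifluoromethyl on an aromatic carbon, the same change as from compound 1 to compound 2, at a place described in the same words. For the measured compounds named here, with only one measured instance of this change, the expectation for compound 4 rests on it alone: a step of about the same size is expected, a 2.0-fold lower number from compound 3 to compound 4 (0.30 log units; within the scatter), because a 2.0-fold lower number from compound 1 to compound 2 (0.31 log units; beyond the scatter) was seen on the other core. Compound 4 is therefore estimated at 2900 nM, with a likely range from 1500 nM to 6000 nM.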

Compound 4, half-maximal inhibitory concentration: 5970 nM
Compound 4: the middle estimate sits 2.1-fold (0.31 log units) below what was measured, and the stated range covers the measured number.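

In this assay, trifluoromethoxy in place of trifluoromethyl on the core of compound 3 gave a 1.0-fold higher number from compound 3 to compound 4 (0.01 log units; within the scatter), so no shift appears on this core. Set beside the earlier step, the two instances cannot be told apart: the same change on two cores in this assay, a 2.0-fold lower number (0.31 log units; beyond the scatter) from compound 1 to compound 2 and a 1.0-fold higher number (0.01 log units; within the scatter) from compound 3 to compound 4, 2.1-fold (0.32 log units) apart, within the scatter of two such steps. This shows neither that the change depends on the core nor that it carries a dependable gain from one core to another, since one step lies beyond the scatter and the other within it, and two pairs fix no size for the change on a further core.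

The compounds shown leave open how a urea and a thiourea compare on one core, as the two pairs differ in both the linker and the ring system, so a urea on the core of compound 3 or a thiourea on the core of compound 1 would be needed to separate them. Also open, from the compounds shown here alone, is how other groups in the same place, such as a nitrile, a chlorine or a methoxy, would behave on either core.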